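A few compounds are considered here, and "the series" means these few. Any claim that something is new, unique, unknown or untested is made for them only; others in the source may bear on it.

Compound 2 `COc1ccc(-c2cc3ccccc3c(-c3cccc(OC)c3)n2)cc1` gives 1300 nM in a functional assay on HCT-15 cells (Homo sapiens) for cytotoxicity, read by CCK-8 assay and cell counting, with a stated time of 72 h (on this read-out lower numbers stand for stronger inhibition and higher numbers for weaker inhibition), the higher of the two numbers measured, and compound 1 `COc1ccc(-c2cc3ccccc3c(-c3cccc(O)c3)n2)cc1`, which carries a hydroxyl in place of the methoxy, gives 1200 nM in this assay; the two values lie within the scatter of each other. Among the measured compounds shown here, the one step measured so far at this position, a 1.1-fold higher number from compound 1 to compound 2 (0.03 log units; within the scatter), was within the scatter. Compound 3 `COc1ccc(-c2cc3ccccc3c(-c3cccc(N)c3)n2)cc1` differs from compound 2 by amino in place of methoxy on an aromatic carbon. For the measured compounds named here, no measured step covers an amino at this position; the only guidance is that the hydroxyl-to-methoxy step left the number within the scatter. The expectation for compound 3 is therefore a step of a 1.1-fold lower number from compound 2 to compound 3 (0.03 log units; within the scatter) in this assay, a change not beyond the scatter in either direction. Compound 3 is estimated at 1200 nM, with a range from 500 nM to 3000 nM.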

Compound 3, half-maximal inhibitory concentration: 2350 nM
Compound 3: middle estimate off by 2.0-fold (0.29 log units), on the low side, within the range that was stated.
By their numbers in this assay, from the lowest: compounds 1, 2 and 3 (each within the scatter of the next).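

Amino in place of methoxy on this aromatic carbon, giving a 3-aminophenyl, stays inside the scatter in this assay: the data show a 1.8-fold higher number from compound 2 to compound 3 (0.26 log units; within the scatter), and against the hydroxyl they show a 2.0-fold higher number from compound 1 to compound 3 (0.29 log units; within the scatter). With a nitrogen-bearing group now tested alongside the two oxygen-bearing ones, compounds 1, 2 and 3 still cannot be separated on these numbers, so none of the three groups can be ranked at this position. Nothing available explains these numbers.

The compounds shown leave open whether a larger or charged group here, such as a carboxylic acid, a dimethylamino group or an acetamide, would move the number beyond the scatter. They also leave open what replacing the other methoxy, which all three compounds share, would do in this assay.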